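A few compounds are considered here, and "the series" means these few. Any claim that something is new, unique, unknown or untested is made for them only; others in the source may bear on it.

The study concerns a functional assay on A549 cells (Homo sapiens) for cytotoxicity, read by MTT assay, with a stated time of 24 h; on this read-out higher numbers stand for weaker inhibition and lower numbers for stronger inhibition. Compound 1 `CCOC(=O)N1CCC(=NNC(=O)c2ccc([N+](=O)[O-])cc2)CC1` is one of two measured compounds sharing a core. In this assay compound 1 gives only a limit, > 400000 nM. Compound 2 `CCOC(=O)N1CCC(=NNC(=O)c2ccc([N+](=O)[O-])cc2[N+](=O)[O-])CC1` differs from compound 1 by nitro in place of hydrogen on an aromatic carbon, and in this assay compound 2 gives 27300000 nM. The step that the limit leaves unreadable from compound 1 to compound 2 cannot be sized, since the limit of > 400000 nM in this assay, at which 2 of the 3 values shown sit, leaves it unreadable. Compound 3 `O=C(NN=C1CC(c2ccccc2)NC(c2ccccc2)C1)c1ccc([N+](=O)[O-])cc1` stands on another core, and the difference between the two cores is not broken down here. In this assay compound 3 gives only a limit, > 400000 nM. Compound 4 `O=C(NN=C1CC(c2ccccc2)NC(c2ccccc2)C1)c1ccc([N+](=O)[O-])cc1[N+](=O)[O-]` has not been measured yet. It differs from compound 3 by nitro in place of hydrogen on an aromatic carbon, the same change as that made from compound 1 to compound 2, at a place described in the same words. For compound 4 the step that the limit leaves unreadable from compound 3 to compound 4 is expected, an expectation that rests on compound 2 giving a readable value of 27300000 nM after the same change. Compound 4 is thus estimated at 20000000 nM, with the expected range running from 2000000 nM to 100000000 nM.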

Compound 4, half-maximal inhibitory concentration: > 400000 nM
Compound 4: a limit, no number (the forecaster's own chance of this, stated with the estimate: 50%); the middle value lies beyond the limit too.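

No new step can be read from compound 3 to compound 4 in this assay, since each of the two compounds gives only a limit: the limit of > 400000 nM in this assay, at which 3 of the 4 values shown sit.

The compounds shown leave open how large the effect of nitro in place of hydrogen is on either core, and whether the two cores respond to it alike.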